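Fluoro in Place of Hydrogen and Cytotoxicity Read-out

The compounds below may be only part of what the source reports. "The series", "measured", "known", "first", "only" and "open" are said of these compounds alone.

Compound 1 `CCNCC1CCN(c2c(F)cc3c(=O)c(C(=O)O)cn(NC)c3c2F)C1`: > 500 ug/mL
Compound 2 `CCNCC1CCN(c2cc3c(cc2F)c(=O)c(C(=O)O)cn3NC)C1`: > 500 ug/mL
Compound 3 `CC1(CN)CCN(c2cc3c(cc2F)c(=O)c(C(=O)O)cn3C2CC2)C1`: 23 ug/mL

Three compounds were tested in a functional assay on V79 cells (Cricetulus griseus) for cytotoxicity, read by colony formation; a higher number here means a weaker inhibitor, a lower number a stronger inhibitor. Compound 1 gives > 500 ug/mL, which is a limit of the assay and not a number. Compound 2 likewise gives > 500 ug/mL, again a limit. Among the compounds with values here, compound 3 gives 23 ug/mL, the only number among the three. The change from compound 2 to compound 1 is fluoro in place of hydrogen on an aromatic carbon; the step it made, a step that the two limits leave unreadable from compound 2 to compound 1, cannot be read because both values sit at the limit of > 500 ug/mL in this assay, at which 2 of the 3 values shown sit. Compound 3 and compound 2 differ in more than one place, and the difference between the two cores is not broken down here. Compound 4 `CC1(CN)CCN(c2c(F)cc3c(=O)c(C(=O)O)cn(C4CC4)c3c2F)C1` remains to be measured in this assay. It differs from compound 3 by fluoro in place of hydrogen on an aromatic carbon, the same kind of change as from compound 2 to compound 1, except that there the fluoro enters ortho to a 3-((ethylamino)methyl)pyrrolidin-1-yl group and here ortho to a 3-(aminomethyl)-3-methylpyrrolidin-1-yl group. Because the earlier step is unreadable and compound 3 gives 23 ug/mL, the step to compound 4 is expected to be small, a 1.5-fold lower number from compound 3 to compound 4 (0.19 log units; within the scatter). Compound 4 is thus estimated at 15 ug/mL, between 5 ug/mL and 60 ug/mL.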

Compound 4, half-maximal inhibitory concentration: 8 ug/mL
Beside the measured number, compound 4's estimate is 1.9-fold (0.27 log units) above it; the range from low to high includes it.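

In this assay, fluoro in place of hydrogen on an aromatic carbon, ortho to a 3-(aminomethyl)-3-methylpyrrolidin-1-yl group, gives a 2.9-fold lower number from compound 3 to compound 4 (0.46 log units; beyond the scatter), so on this core the change yields a modestly stronger cytotoxic read-out. The same kind of change on the other core, from compound 2 to compound 1, cannot be read: the limit of > 500 ug/mL in this assay, at which 2 of the 4 values shown sit. The series therefore gives one readable step on one core, which shows that the change can lower the number but not that this step carries from one core to another, since there is no second size to set it against.

On these data alone, whether the change moves the read-out at all on the core of compound 1 stays open. The compounds shown also leave open whether a chloro or a methoxy group entering at the same aromatic carbon of the core of compound 3 would give a step of similar size.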